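The compounds below may be only part of what the source reports. "The series", "measured", "known", "first", "only" and "open" are said of these compounds alone.

Of the compounds shown here, three sharing one core have been measured so far. Compound 1 `CN1CCC[C@@H]1[C@H]1COc2ccc(O)cc2O1` gives 3500 nM in an assay on Cerebral cortex (strain Sprague-Dawley) for displacement of a labelled ligand from Neuronal acetylcholine receptor; alpha4/beta2 (Rattus norvegicus); on this read-out higher numbers stand for weaker inhibition and lower numbers for stronger inhibition. Compound 2 `Oc1ccc2c(c1)O[C@H]([C@H]1CCCN1)CO2` gives 1300 nM in this assay, and compound 3 `Oc1ccc2c(c1)O[C@@H]([C@@H]1CCCN1)CO2` gives 1200 nM in this assay; that is the lowest number shown, though compound 2 lies within the scatter of it and only compound 1 sits beyond. Compound 4 `Oc1ccc2c(c1)O[C@@H]([C@H]1CCCN1)CO2` has not been measured. The change from compound 3 to compound 4 is the two compounds have the same atoms and bonds and differ only in configuration as drawn: 1 of 2 stereo elements differ; a stereocentre at a saturated ring carbon is drawn S in compound 3 and R in compound 4. For the measured compounds named here, the one measured step that speaks to a change of configuration is a 1.1-fold lower number from compound 2 to compound 3 (0.03 log units; within the scatter), which rests on (the fact that compounds 2 and 3 differ only in the configuration as drawn); there both stereocentres are inverted, here only one. Compound 4 is therefore expected to show a 1.3-fold higher number from compound 3 to compound 4 (0.10 log units; within the scatter), no more than the scatter. Compound 4 is estimated at 1500 nM in this assay, between 500 nM and 4500 nM.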

Compound 4, inhibition constant: 18000 nM
The estimate for compound 4 lay 12-fold (1.08 log units) below the measured number; the measured number lies above the stated range.
By their numbers in this assay, from the lowest: compounds 3 and 2 (each within the scatter of the next); then compound 1; then compound 4.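

In this assay, inverting one stereocentre does what inverting both did not: a 15-fold higher number from compound 3 to compound 4 (1.18 log units; beyond the scatter) and a 14-fold higher number from compound 2 to compound 4 (1.14 log units; beyond the scatter), whereas a 1.1-fold lower number from compound 2 to compound 3 (0.03 log units; within the scatter). What counts here is therefore how the two stereocentres are set relative to each other, not either centre alone: the fact that compounds 3 and 4 differ only in the configuration as drawn With hydrogen in place of methyl on an amine nitrogen in a ring, there is also a 5.1-fold higher number from compound 1 to compound 4 (0.71 log units; beyond the scatter).

From the compounds shown here alone, it remains open whether that methyl would act the same way in the configuration of compounds 2 and 3. Also open, going by these compounds, is whether an ethyl on that nitrogen, or a methoxy in place of the hydroxyl, would preserve the gap between configurations.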